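A few compounds are considered here, and "the series" means these few. Any claim that something is new, unique, unknown or untested is made for them only; others in the source may bear on it.

Among the compounds with values here, in a functional assay on MOLT-4 cells (Homo sapiens) for inhibition, read by MTT assay, with a stated time of 72 h (a higher number here means a weaker inhibitor, a lower number a stronger inhibitor), compound 1 `COc1cc(NC(C)CCCNC(=O)NNC(=O)Nc2ccc(Cl)cc2)c2ncccc2c1` gives 186000 nM, while compound 2 `COc1cc(NC(C)CCCNC(=O)Nc2cccc(O)c2)c2ncccc2c1` gives 24000 nM, the lower of the two numbers so far. Compound 3 `COc1cc(NC(C)CCCNC(=O)Nc2cccc(C(F)(F)F)c2)c2ncccc2c1` has not yet been measured. It differs from compound 2 by trifluoromethyl in place of hydroxy on an aromatic carbon, meta to a large group: trifluoromethyl in place of hydroxy on an aromatic carbon. Within the data shown here, only one measured step is available, a 7.8-fold lower number from compound 1 to compound 2 (0.89 log units; beyond the scatter), and it bears only indirectly. That step puts 3-hydroxyphenyl in place of ((4-chlorophenyl)carbamoyl)amino on an amide-type nitrogen and does not exchange a group on the aromatic carbon. Among the measured compounds shown here, no measured pair isolates the hydroxy group, so the data favour no direction, and no step beyond the scatter is expected in this assay. The expected change is small, a 1.2-fold lower number from compound 2 to compound 3 (0.08 log units; within the scatter). For compound 3 the estimated value is 20000 nM, with an expected range of 7000 nM to 55000 nM.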

Compound 3, half-maximal inhibitory concentration: 20000 nM
The estimate for compound 3 equals the measured number at the digits printed, and the stated range covers the measured number.
By their numbers in this assay, from the lowest: compounds 3 and 2 (each within the scatter of the next); then compound 1.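

In this assay, trifluoromethyl in place of hydroxy on the aromatic carbon, meta to a large group, gives a 1.2-fold lower number from compound 2 to compound 3 (0.08 log units; within the scatter), so a group with a hydrogen-bond donor and acceptor and one with neither read alike at this place, which compound 1 and compound 2 alone could not show. The gain over compound 1 also does not depend on the hydroxy group, as 3-(trifluoromethyl)phenyl on the amide-type nitrogen gives a 9.3-fold lower number from compound 1 to compound 3 (0.97 log units; beyond the scatter) and remains beyond the scatter. No measurement at hand explains this result.

Going by these compounds, whether an amine or a carboxylic acid on this same aromatic carbon would also leave the number unmoved stays open. So does whether a longer chain in the shared scaffold would shift the number in this assay at all.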